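The source may hold more compounds than are shown below. What is called first, only, known or untested is meant among the compounds shown, and "the series" means these compounds.

Measured compounds:
- compound 1, `C/C=C/C(=O)N(Cc1ccc(OC)c([N+](=O)[O-])c1)c1cc(OC)c(OC)c(OC)c1`: 510 nM
- compound 2, `CCCCC(=O)N(Cc1ccc(OC)c(O)c1)c1cc(OC)c(OC)c(OC)c1`: 300 nM
- compound 3, `COc1ccc(CNc2cc(OC)c(OC)c(OC)c2)cc1Br`: 39800 nM

All three were tested in a functional assay on KYSE-450 cells (Homo sapiens) for inhibition, read by MTT assay, with a stated time of 48 h; on this read-out lower numbers stand for stronger inhibition and higher numbers for weaker inhibition. Compound 2 gives 300 nM, the lowest of the three numbers. Compound 1, with 510 nM, sits close to it, and the gap between the two lies within the scatter of this assay, so no order between compound 1 and compound 2 can be read from these numbers. Compound 3, with 39800 nM, stands far away from both, a gap well beyond the scatter.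

The next compound, compound 4, `COc1ccc(CN(C(=O)/C=C/CBr)c2cc(OC)c(OC)c(OC)c2)cc1O`, has not yet been measured in this assay. It differs from compound 2 in one place:

3-bromoprop-1-en-1-yl in place of butyl on a carbonyl carbon

The rest of the molecule, the shared core with its hydroxyl and methoxy groups, stays as in compound 2. For the measured compounds named here, no measured pair shows this exact exchange, so the size of the step is open. Compound 1, which carries a double bond in the same part of the molecule, gives 510 nM, and that number lies within the scatter of compound 2, which suggests a small step. The step of a 1.5-fold lower number from compound 2 to compound 4 (0.18 log units; within the scatter) is therefore expected to stay within or near the scatter. For compound 4 the estimate is 200 nM, with a range from 60 nM to 700 nM.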

Compound 4, half-maximal inhibitory concentration: 100 nM
Estimate against measurement, compound 4: 2.0-fold (0.30 log units) above; measured number inside the range.
By their numbers in this assay, from the lowest: compound 4; then compounds 2 and 1 (each within the scatter of the next); then compound 3.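

In this assay, for the compounds shown here, the exchange of butyl for 3-bromoprop-1-en-1-yl on a carbonyl carbon gives a 3.0-fold lower number from compound 2 to compound 4 (0.48 log units; beyond the scatter) and is the first step at this position that can be read at all, since the earlier compounds offered no pair differing in one place. It is a modest step, but it shows that the number responds to the group on this carbonyl carbon, even though the leaving and entering groups have the same count of heavy atoms and neither brings a ring or a net charge. No measurement shown here explains why the number changes in this way.

The exchange brings in a double bond and a bromine at once, and this single step cannot tell whether one of them, or only the two together, accounts for the lower number; a saturated 3-bromopropyl group or an unsubstituted prop-1-en-1-yl group on the same carbonyl carbon, with the rest of compound 4 unchanged, would separate the two. From the compounds shown here alone, how a chlorine or an amine in place of the bromine would read also stays open.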